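A Nitro Group in Place of Methyl on the Quinoxaline-Free Core

A few compounds are considered here, and "the series" means these few. Any claim that something is new, unique, unknown or untested is made for them only; others in the source may bear on it.

Measured so far:
Compound 1, `CCCCCCCCc1nc2ccc(C)cc2nc1CCCCCCCC(=O)O`, gives 12.5% in a functional assay on the whole organism for inhibition, with Rattus norvegicus as the target, read by paw edema, with a stated time of 3 h, at a dose of 100 mg/kg by the oral route; a higher number here means more inhibition at the dose given (going by the name of the read-out), a lower number less inhibition.
Compound 2, `CCCCCCCCC1=NC(=O)N=C1CCCCCCCC(=O)O`, gives -12.9% in this assay.
Compound 3, `CCCCCCCCC1=NC(=O)N=C1CCCCCCCC(=O)NN1C(=O)CSC1c1ccc(Cl)cc1`, gives 0% in this assay.

Among these three numbers compound 1 stands highest. Its nearest neighbour is compound 3, whose number lies lower by a gap beyond the usual scatter, and the furthest is compound 2, whose number lies lower still, also beyond the scatter. Among the measured compounds shown here, compounds 2 and 3 share a different core from compound 1, so no single-change step between measured compounds is available, and their values can only be read as they stand.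

The next compound, compound 4, `CCCCCCCCc1nc2ccc([N+](=O)[O-])cc2nc1CCCCCCCC(=O)O`, keeps the core and the long chain ending in a carboxylic acid of compound 1 and differs in one place: nitro in place of methyl on an aromatic carbon. For the measured compounds named here, no measured pair shows what such an exchange does in this assay, so there is no basis for expecting a move in either direction. The step from compound 1 to compound 4 is therefore expected to be none beyond the scatter, a number 0.5 percentage points lower from compound 1 to compound 4 (within the scatter). On that footing compound 4 is estimated at 12%, with a range from -8% to 30%.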

Compound 4, a percentage reported as inhibition, in the whole organism at one dose (the size of the read-out at that dose, not a potency): 39.6%
Compound 4: the middle estimate sits 27.6 percentage points below what was measured; measured number outside the range, above it.
By their numbers in this assay, from the lowest: compound 2; then compound 3; then compound 1; then compound 4.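

In this assay, the aromatic carbon bearing the methyl group in compound 1 proves sensitive to change: with the core, the long chain and the carboxylic acid left as they are, nitro in place of methyl gives a number 27.1 percentage points higher from compound 1 to compound 4 (beyond the scatter) and so moves the number beyond the usual scatter. Among the compounds shown here, this is the first single-change step available here, so it is the first direct sign that a group on this six-membered aromatic ring can alter the inhibition of paw edema, although the step is only modest in size. Nothing measured here says why the number rises with this exchange.

Going by these compounds, one pair cannot show whether the gain belongs to nitro alone, and it remains open whether an amine, a nitrile or a plain hydrogen on the same aromatic carbon would give a number closer to that of compound 1 or that of compound 4. On these data alone, it is also open whether the same exchange would have a similar effect on another aromatic carbon of this ring, or at another dose or time.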